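Bromine Added to the Hydroxyphenyl Hydrazone: Expected Cytotoxicity

A few compounds are considered here, and "the series" means these few. Any claim that something is new, unique, unknown or untested is made for them only; others in the source may bear on it.

Three compounds have been measured in an ADME assay on NIH3T3 cells (Mus musculus) for cytotoxicity, read by MTT assay, with a stated time of 24 h; on this read-out higher numbers stand for weaker inhibition and lower numbers for stronger inhibition:

compound 1 `O=C(CSc1nnc(-c2ccncc2)o1)N/N=C/c1ccc(Cl)cc1`: 181000 nM
compound 2 `O=C(CSc1nnc(-c2ccncc2)o1)N/N=C/c1ccc(O)cc1`: 158000 nM
compound 3 `O=C(CSc1nnc(-c2ccncc2)o1)N/N=C/c1ccccc1O`: 155000 nM

Compound 2 sits among the three with every step to its neighbours inside the usual repeat variation: a 1.1-fold lower number from compound 1 to compound 2 (0.06 log units; within the scatter) and a 1.0-fold lower number from compound 2 to compound 3 (0.01 log units; within the scatter) are both within the scatter, as is a 1.2-fold lower number from compound 1 to compound 3 (0.07 log units; within the scatter). Compound 4 `O=C(CSc1nnc(-c2ccncc2)o1)N/N=C/c1cc(Br)ccc1O` differs from compound 2 in one place: 5-bromo-2-hydroxyphenyl in place of 4-hydroxyphenyl on a carbon with a double bond to nitrogen. Going by the values given here, no measured step introduces a bromine, so only these three small steps bear on the change, and none of them moves the read-out beyond the scatter. A step of similar size, in no firm direction, is therefore expected for compound 4 in this assay. Compound 4 is expected to give 140000 nM, with a range from 70000 nM to 280000 nM. This estimate corresponds to an expected step of a 1.1-fold lower number from compound 2 to compound 4 (0.05 log units; within the scatter).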

Compound 4, half-maximal inhibitory concentration: 156000 nM
Compound 4: middle estimate off by 1.1-fold (0.05 log units), on the low side; measured number inside the range.
By their numbers in this assay, from the lowest: compounds 3, 4, 2 and 1 (each within the scatter of the next).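

In this assay, going by these compounds alone, the bromo in place of hydrogen on an aromatic carbon gives the first measured step that introduces a bromine (a 1.0-fold higher number from compound 3 to compound 4 (0.00 log units; within the scatter)). The larger replacements at this carbon with a double bond to nitrogen also stay level (a 1.0-fold lower number from compound 2 to compound 4 (0.01 log units; within the scatter)) (a 1.2-fold lower number from compound 1 to compound 4 (0.06 log units; within the scatter)), so the 5-bromo-2-hydroxyphenyl group is not told apart from the other aryl groups on this read-out. No evidence is available that bears on this result.

Going by these compounds, whether an amine or a carboxylic acid on this aromatic ring would move the number beyond the scatter remains open. So does whether any change at this position can do so.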